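Pyridyl Amide in Place of Fluorocyclobutyl Amide

This account rests on a few compounds, and the source may have more. Where it says the series, first, only, none or still open, it means among the compounds named here.

Compound 1 `CCN1CCc2nc(C#Cc3ccccc3)sc2C1` gives 1200 nM in an assay on HEK293 cells for negative allosteric modulation of metabotropic glutamate receptor 5 (Homo sapiens), read by FLIPR, with a stated time of 1 h; a higher number here means a weaker inhibitor, a lower number a stronger inhibitor.
Compound 2 `CCCCN1CCc2nc(C#Cc3ccccc3)sc2C1` gives > 10000 nM, a limit of the assay.
Compound 3 `O=C(C1CC(F)C1)N1CCc2nc(C#Cc3ccccc3)sc2C1` gives > 10000 nM, a limit of the assay.

Compound 3 sits at the limit of > 10000 nM in this assay, at which 2 of the 3 values shown sit, so its inhibition is too weak to be given as a number. Compound 4 `Cc1cccc(C(=O)N2CCc3nc(C#Cc4ccccc4)sc3C2)n1` differs from it in one place: 6-methylpyridin-2-yl in place of 3-fluorocyclobutyl on a carbonyl carbon. The step from compound 1 to compound 3, an at least 8.3-fold higher number from compound 1 to compound 3 (0.92 log units; beyond the scatter), shows that an amide on the ring nitrogen weakens inhibition beyond the scatter; the step that the two limits leave unreadable from compound 2 to compound 3 stays unreadable. For the measured compounds named here, compound 4 keeps the amide, and no measured step tells how a change of its acyl group acts. Compound 4 is therefore expected to stay weak, with an estimated 10000 nM, between 3000 nM and 30000 nM, the expected step being a number no higher from compound 3 to compound 4 (the limit leaves the size open).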

Compound 4, half-maximal inhibitory concentration: > 10000 nM
Compound 4: a limit, no number; the forecaster's own chance of this, stated with the estimate: 60%; the middle value lies on the limit itself.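

For the compounds shown here, compound 3 and compound 4 both stand at a limit of the assay, not at a number, so no step between them can be read: the limit of > 10000 nM in this assay, at which 3 of the 4 values shown sit.
The compounds shown leave open how strongly either compound inhibits, and whether 6-methylpyridin-2-yl in place of 3-fluorocyclobutyl changes inhibition at all.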